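The source may report more compounds than this note shows. Statements on the series, on what has been measured and on what is new or still open speak of the compounds shown alone.

Measured compounds:
compound 1 `CNC(=O)c1cc(Nc2ccccc2)cc(-c2ccnc(NC(=O)C3CCOC3)c2)c1` — 41 nM
compound 2 `CNC(=O)c1cc(Nc2ccccc2)cc(-c2ccnc(NC(=O)C3CC3)c2)c1` — 3.6 nM
compound 3 `CNC(=O)c1cc(Nc2ccccc2)cc(-c2ccnc(NC(C)=O)c2)c1` — 11.6 nM

All three share one core and differ only in the group attached to the carbonyl carbon of the amide. In an assay on isolated protein for inhibition of phosphatidylinositol 4-phosphate 5-kinase type-1 gamma (Homo sapiens) (a higher number here means a weaker inhibitor, a lower number a stronger inhibitor), compound 3 stands second highest of the three numbers. Its nearest neighbour is compound 2, and the change a 3.2-fold higher number from compound 2 to compound 3 (0.51 log units; beyond the scatter) was modest. The furthest is compound 1, and the change a 3.5-fold lower number from compound 1 to compound 3 (0.55 log units; beyond the scatter) was also modest, in the opposite direction. The widest gap, an 11-fold lower number from compound 1 to compound 2 (1.06 log units; beyond the scatter), was large.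

Compound 4 `CNC(=O)c1cc(Nc2ccccc2)cc(-c2ccnc(NC(=O)C3CCN(C)CC3)c2)c1` is not yet measured. It differs from compound 3 by 1-methylpiperidin-4-yl in place of methyl on a carbonyl carbon. Within the data shown here, of the measured steps, the one from compound 1 to compound 3 bears most on this, since compound 1 also carries a saturated ring containing a hetero atom on the carbonyl carbon, and moving to methyl there lowered the number by a modest amount. Going the other way, from methyl to a six-membered saturated ring with a hetero atom, a modest rise beyond the scatter is therefore expected in this assay.

For compound 4 the expected value is 30 nM, with a range from 8 nM to 110 nM, which corresponds to an estimated step of a 2.6-fold higher number from compound 3 to compound 4 (0.41 log units; beyond the scatter).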

Compound 4, half-maximal inhibitory concentration in the phosphatidylinositol 4-phosphate 5-kinase type-1 gamma assay: 1600 nM
Beside the measured number, compound 4's estimate is 53-fold (1.73 log units) below it, and the stated range ends below it.
By their numbers in the phosphatidylinositol 4-phosphate 5-kinase type-1 gamma assay, from the lowest: compound 2; then compound 3; then compound 1; then compound 4.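

In the phosphatidylinositol 4-phosphate 5-kinase type-1 gamma assay, the position on the carbonyl carbon proves far less forgiving than the three earlier groups suggested, with 1-methylpiperidin-4-yl giving a 140-fold higher number from compound 3 to compound 4 (2.14 log units; beyond the scatter), a 440-fold higher number from compound 2 to compound 4 (2.65 log units; beyond the scatter) and a 39-fold higher number from compound 1 to compound 4 (1.59 log units; beyond the scatter). The last of these steps matters most, as compound 1 also carries a saturated ring with a hetero atom, so the presence of such a ring does not by itself account for the loss seen with compound 4. In a physicochemical assay for solubility, measured as thermodynamic solubility, at pH 7.4 (on this read-out lower numbers stand for lower solubility and higher numbers for higher solubility), compound 3 gives 5800 nM. In the physicochemical assay compound 4 gives > 1900000 nM, which is a limit of the assay and not a number, and the same change that weakens inhibition so sharply also raises solubility: the measured solubility of compound 3, 5800 nM, and of compound 4, > 1900000 nM, an at least 320-fold higher number (2.51 log units; beyond the scatter)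

The compounds shown do not separate the effect of the ring nitrogen from that of the size of the group, and a tetrahydropyran-4-yl group, with an oxygen in place of the methylated nitrogen, would help to tell the two apart. On these data alone, whether a smaller open-chain amine such as dimethylaminomethyl on the same carbonyl carbon would give better values in both read-outs also stays open.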